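This account rests on a few compounds, and the source may have more. Where it says the series, first, only, none or still open, it means among the compounds named here.

Working notes on the series, read in an ADME assay on MDCK cells (Canis lupus familiaris) for cytotoxicity, read by MTT assay, with a stated time of 24 h; a lower number here means that less compound is tolerated, a higher number that more compound is tolerated. Compound 1 (`N#Cc1ccc(S(=O)(=O)NCc2csc3ccccc23)cc1`) gives 122000 nM, compound 2 (`O=S(=O)(NCc1csc2ccccc12)c1ccc(Cl)cc1`) gives 69600 nM, and compound 3 (`O=S(=O)(NCc1csc2ccccc12)c1ccc(Br)cc1`) gives 87100 nM. Compound 3 is not separated from either neighbour: the steps are a 1.3-fold higher number from compound 2 to compound 3 (0.10 log units; within the scatter) and a 1.4-fold lower number from compound 1 to compound 3 (0.15 log units; within the scatter). The remaining measured step, a 1.8-fold lower number from compound 1 to compound 2 (0.24 log units; within the scatter), is no larger in kind.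

Next is compound 4 (`CC(=O)c1ccc(S(=O)(=O)NCc2csc3ccccc23)cc1`), with acetyl in place of bromo on an aromatic carbon, para to a large group: acetyl in place of bromo on an aromatic carbon. All three measured steps exchange the group at this place, and none of them leaves the scatter. For the measured compounds named here, none of them involves acetyl, so the data hold no direct precedent for this group, and the nearest guide is the cyano, chloro and bromo set. The expected size in this assay is therefore nil beyond the scatter, with no favoured direction. The estimated step is a 1.1-fold higher number from compound 3 to compound 4 (0.04 log units; within the scatter). For compound 4 the estimated value is 95000 nM, with an expected range of 45000 nM to 190000 nM.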

Compound 4, half-maximal cytotoxic concentration: > 193000 nM
Compound 4 gave a limit, no number; the forecaster's own chance of this, stated with the estimate: 10%; middle value at least 2.0-fold (0.30 log units) away from the limit.
By their numbers in this assay, from the lowest: compounds 2, 3 and 1 (each within the scatter of the next). At a limit, above all of these: compound 4.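

In this assay compound 4 gives > 193000 nM, which is a limit and not a number. For the compounds shown here, with acetyl on this aromatic carbon, a change at this position leaves the scatter for the first time, whereas the exchanges among cyano, chloro and bromo did not: an at least 2.2-fold higher number from compound 3 to compound 4 (0.34 log units; beyond the scatter) and an at least 2.7-fold higher number from compound 2 to compound 4 (0.44 log units; beyond the scatter) are both floors on the true step. Against the nitrile the separation is not established, since an at least 1.5-fold higher number from compound 1 to compound 4 (0.19 log units; that floor lies within the scatter) is only a floor, so acetyl stands apart from the two halogens alone.

Going by these compounds, how far compound 4 lies past its limit stays open, and with it whether compound 4 truly differs from compound 1. The compounds shown also do not tell whether an amide, a carboxylic acid or a longer acyl chain at this place would read like acetyl.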